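The compounds below may be only part of what the source reports. "The series", "measured", "known", "first", "only" and "open" are said of these compounds alone.

Compound 3 `Cc1ccc(S(=O)(=O)N2CC=C(Br)CC2)cc1` is the bromo counterpart of compound 2 `Cc1ccc(S(=O)(=O)N2CC=C(Cl)CC2)cc1`. In a functional assay on WiDr cells (Homo sapiens) for antiproliferative activity, read by sulforhodamine B assay, with a stated time of 48 h (on this read-out lower numbers stand for stronger inhibition of growth and higher numbers for weaker inhibition of growth), compound 3 gives only a limit, > 100000 nM. Compound 2 likewise gives only a limit in this assay, > 100000 nM. The step that the two limits leave unreadable from compound 2 to compound 3 therefore cannot be read, since both values sit at the limit of > 100000 nM in this assay, at which 2 of the 3 values shown sit. For the measured compounds named here, compound 1 `Cc1ccc(S(=O)(=O)N2CC[C@@H](Cl)C[C@@H]2c2ccccc2)cc1`, which carries a chloro group on a saturated ring carbon and a phenyl group on the shared core, gives 37000 nM in this assay; it differs from compound 3 in more than one place, so its value shows only that a measurable number is reached with a carbocyclic group on the core. Compound 4 `Cc1ccc(S(=O)(=O)N2CCC(Br)=CC2C2CCCCC2)cc1` differs from compound 3 by cyclohexyl in place of hydrogen on a saturated ring carbon. Going by the values given here, no measured step covers this change, and compound 3 itself stands at a limit, so the size of any step is open. Compound 4 is nonetheless expected to give about 50000 nM, in a range from 15000 nM to 200000 nM. The step of an at least 2.0-fold lower number from compound 3 to compound 4 (0.30 log units; that floor lies within the scatter) is thus expected to run toward stronger inhibition, read against a limit.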

Compound 4, concentration for 50% growth inhibition: 18000 nM
For compound 4 the middle estimate is 2.8-fold (0.44 log units) above the measured one; the range from low to high includes it.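

In this assay, for the compounds shown here, cyclohexyl in place of hydrogen on a saturated ring carbon next to the ring nitrogen gives an at least 5.5-fold lower number from compound 3 to compound 4 (0.74 log units; beyond the scatter), the first step in this set whose size can be read. Compound 4 is the only compound shown with a halogen on a double-bonded ring carbon that gives a number rather than a limit, so this position accepts a carbon-only ring with a gain in growth inhibition. The size of the step is only a floor, since the value of compound 3 is a limit: the limit of > 100000 nM in this assay, at which 2 of the 4 values shown sit.

On these data alone, whether the gain needs the cyclohexyl ring itself stays open, as nothing shows what a methyl group, a longer chain or an amine would do on the same carbon. As far as these compounds go, it is also open whether chloro in place of bromo would hold up in the presence of cyclohexyl.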